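Positional isomers of the methoxycarbonyl group: toxicity notes

A few compounds are considered here, and "the series" means these few. Any claim that something is new, unique, unknown or untested is made for them only; others in the source may bear on it.

Compound 3 `CCOC(=O)c1cnc(N2CCN(Cc3cccc(C(=O)OC)c3)CC2)nc1Oc1c(C)cc(-c2ccc(C#N)cc2)cc1C` is one of three analogues sharing a core. In an ADME assay on MT4 cells (Homo sapiens) for cytotoxicity, read by MTT assay, with a stated time of 4 days (on this read-out higher numbers stand for lower toxicity in this test and lower numbers for higher toxicity in this test), compound 3 gives only a limit of > 125000 nM. Compound 1 `CCOC(=O)c1cnc(N2CCN(Cc3ccccc3C#N)CC2)nc1Oc1c(C)cc(-c2ccc(C#N)cc2)cc1C` likewise gives only a limit of > 125000 nM in this assay. Compound 2 `CCOC(=O)c1cnc(N2CCN(Cc3ccc(C(=O)OC)cc3)CC2)nc1Oc1c(C)cc(-c2ccc(C#N)cc2)cc1C` gives only a limit of > 125000 nM. Accordingly a step that the two limits leave unreadable from compound 1 to compound 2, a step that the two limits leave unreadable from compound 1 to compound 3 and a step that the two limits leave unreadable from compound 2 to compound 3 cannot be sized, as shown by the limit of > 125000 nM in this assay, at which 3 of the 3 values shown sit. Compound 4 `CCOC(=O)c1cnc(N2CCN(Cc3ccccc3C(=O)OC)CC2)nc1Oc1c(C)cc(-c2ccc(C#N)cc2)cc1C` differs from compound 3 by 2-(methoxycarbonyl)phenyl in place of 3-(methoxycarbonyl)phenyl on a saturated chain carbon bound to an amine nitrogen in a ring. The measured steps that move the methoxycarbonyl group around the ring all left no readable size, so no step beyond the scatter is expected; the expected step is a step that the limit leaves unreadable from compound 3 to compound 4. Compound 4 is estimated at 200000 nM, with a range from 125000 nM to 500000 nM, most likely again reported only as a limit.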

Compound 4, half-maximal cytotoxic concentration: > 125000 nM
Compound 4: a limit, no number; the forecaster's own chance of this, stated with the estimate: 85%; the middle value lies beyond the limit too.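

For the compounds shown here, compound 4, like compound 1, compound 2 and compound 3, gives only a limit in this assay, so no step among them can be read: the limit of > 125000 nM in this assay, at which 4 of the 4 values shown sit. The compounds shown leave open where each true half-maximal cytotoxic concentration lies, and whether moving the methoxycarbonyl group changes it.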